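Fluoro for Trifluoromethyl in a Cyanoaziridine Urea Series

The source may hold more compounds than are shown below. What is called first, only, known or untested is meant among the compounds shown, and "the series" means these compounds.

Measured compounds:
compound 1 `N#CC1CN1C(=O)Nc1ccc(Cl)cc1Cl` — 35000 nM
compound 2 `N#CC1CN1C(=O)Nc1ccc([N+](=O)[O-])cc1` — 6500 nM
compound 3 `N#CC1CN1C(=O)Nc1ccc(C(F)(F)F)cc1` — 5900 nM

Three ureas built on the shared core have been measured in a functional assay on OVCAR-3 cells (Homo sapiens) for inhibition; on this read-out lower numbers stand for stronger inhibition and higher numbers for weaker inhibition. Compound 1 gives 35000 nM, compound 2 gives 6500 nM and compound 3 gives 5900 nM. Compound 3 has the lowest of the three numbers, but its neighbour compound 2 lies within the scatter of it: the step of a 1.1-fold lower number from compound 2 to compound 3 (0.04 log units; within the scatter). Only compound 1 stands clearly apart, with a number well above that of compound 3.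

The next compound, compound 4 `N#CC1CN1C(=O)Nc1ccc(F)cc1`, has not yet been measured in this assay. It differs from compound 3 in one place: fluoro in place of trifluoromethyl on an aromatic carbon.

Among the compounds with values here, no measured step swaps one of these groups for the other, so nothing among the three measured compounds bears directly on this change. Within the data shown here, the one single-place step seen, from nitro to trifluoromethyl, was within the scatter. Compound 4 is therefore expected to land near compound 3, with a modest drift toward a higher number left open: the expected step is a 1.5-fold higher number from compound 3 to compound 4 (0.18 log units; within the scatter). For compound 4 the estimate in this assay is 9000 nM, in a range from 3000 nM to 30000 nM.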

Compound 4, half-maximal inhibitory concentration: 5900 nM
Estimate against measurement, compound 4: 1.5-fold (0.18 log units) above; the range from low to high includes it.
By their numbers in this assay, from the lowest: compounds 3, 4 and 2 (each within the scatter of the next); then compound 1.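

In this assay, within the data shown here, replacing trifluoromethyl, with its 4 heavy atoms, by fluoro, with 1, gives no change at the digits printed from compound 3 to compound 4 (within the scatter), the first direct evidence that this exchange on the aromatic carbon leaves the read-out within the scatter. The comparison with nitro points the same way, with a 1.1-fold lower number from compound 2 to compound 4 (0.04 log units; within the scatter), so all three single-place steps among compounds 2, 3 and 4 now lie within the scatter, and at this position the three groups cannot be told apart by this read-out. The material at hand gives no measured property of these groups that could account for this, and no explanation is offered here.

The groups shown at this carbon are only nitro, trifluoromethyl and fluoro, so it remains open whether an amine, a carboxylic acid or a longer chain in the same place would stay within the scatter of compounds 2, 3 and 4. No single-place step shown here moves the number beyond the scatter, which leaves open whether any change at this position can do so.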